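Dropping One Trifluoromethyl From a Diaryl Urea

The compounds below may be only part of what the source reports. "The series", "measured", "known", "first", "only" and "open" are said of these compounds alone.

Compound 1, `O=C(Nc1cccc(-n2cc(-c3ccncc3)c(-c3cc(O)cc(Cl)c3)n2)c1)Nc1ccc(Cl)c(C(F)(F)F)c1`, gives -55% in a functional assay on OVCAR-5 cells (Homo sapiens) for inhibition, read by sulforhodamine B assay, with a stated time of 48 h, tested at 100 uM; on this read-out lower numbers stand for a stronger effect and higher numbers for a weaker effect at the one concentration tested.
Compound 2, `O=C(Nc1cccc(-n2cc(-c3ccncc3)c(-c3cc(O)cc(Cl)c3)n2)c1)Nc1ccc(Cl)c(Cl)c1`, gives -80% in this assay.
Compound 3, `COc1cc(Cl)cc(-c2nn(-c3cccc(NC(=O)Nc4cc(C(F)(F)F)cc(C(F)(F)F)c4)c3)cc2-c2ccncc2)c1`, gives -80% in this assay.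

In this assay compound 3 stands level with compound 2 at the digits shown, and the two together are the lowest of the three numbers; compound 1 lies a clear distance higher. The one step recorded among these compounds is a number 25 percentage points lower from compound 1 to compound 2 (beyond the scatter), and it shows that a change at the urea-bearing aryl ring can move the number beyond the scatter.

Compound 4, `COc1cc(Cl)cc(-c2nn(-c3cccc(NC(=O)Nc4cccc(C(F)(F)F)c4)c3)cc2-c2ccncc2)c1`, differs from compound 3 in a single way: hydrogen in place of trifluoromethyl on an aromatic carbon. Going by the values given here, no measured pair shows exactly this change, so the step from compound 1 to compound 2 is only an indirect guide. Among the compounds with values here, since compound 3 already gives -80% and the only known change at that ring moved the number in one direction, a step upward, toward a weaker effect, is expected for compound 4, though its size is uncertain. The expected step is a number 25 percentage points higher from compound 3 to compound 4 (beyond the scatter). Compound 4 is therefore estimated at -55%, with a range from -85% to -20%.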

Compound 4, a percentage reported as activity, at one concentration (the size of the read-out at that concentration, not a potency): -13%
Beside the measured number, compound 4's estimate is 42 percentage points below it; measured number above the stated range.
By their numbers in this assay, from the lowest: compounds 2 and 3 (each within the scatter of the next); then compound 1; then compound 4.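

In this assay, taking away one trifluoromethyl and leaving hydrogen on that aromatic carbon, meta to a trifluoromethyl group, gives a number 67 percentage points higher from compound 3 to compound 4 (beyond the scatter) and so shows that this single place carries much of the read-out, even with the other trifluoromethyl still in the molecule. Going by these compounds alone, the only earlier step, a number 25 percentage points lower from compound 1 to compound 2 (beyond the scatter) as chloro replaced trifluoromethyl, exchanged one substituent for another and moved the number the opposite way, whereas here a group of 4 heavy atoms leaves and only a hydrogen atom enters. Nothing available here accounts for the size of this step or for the opposite directions of the two steps.

From the compounds shown here alone, it remains open whether a methyl, a fluoro, a chloro or a methoxy at this place of compound 4 would restore the stronger effect seen with trifluoromethyl, or whether the effect requires trifluoromethyl itself. Going by these compounds, it is equally open whether hydrogen in place of trifluoromethyl would move the number as far on the hydroxy-bearing core of compound 1, where the ring carries its substituents differently.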